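The source may report more compounds than this note shows. Statements on the series, on what has been measured and on what is new or still open speak of the compounds shown alone.

Measured in an ADME assay on BJ cells (Homo sapiens) for cytotoxicity, with a stated time of 72 h; on this read-out higher numbers stand for an effect only at larger amounts of compound and lower numbers for an effect already at smaller amounts:
Compound 1 `Cc1cc(NC(=O)Nc2ccc(F)cc2)c2ccccc2n1`: > 25000 nM, a limit
Compound 2 `COC(=O)c1ccc(NC(=O)Nc2cc(C)nc3ccccc23)cc1`: 21000 nM
Compound 3 `Cc1cc(NC(=O)Nc2ccc(C(F)(F)F)cc2)c2ccccc2n1`: > 25000 nM, a limit

Compound 3 therefore has no exact number, only a limit, and that limit is shared: the limit of > 25000 nM in this assay, at which 2 of the 3 values shown sit. Compound 4 `Cc1cc(NC(=O)Nc2ccc(O)cc2)c2ccccc2n1` carries hydroxy in place of trifluoromethyl on an aromatic carbon, para to a large group: hydroxy in place of trifluoromethyl on an aromatic carbon.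

Three measured steps change this same place: an at least 1.1-fold lower number from compound 1 to compound 2 (0.07 log units; that floor lies within the scatter), an at least 1.1-fold higher number from compound 2 to compound 3 (0.07 log units; that floor lies within the scatter) and a step that the two limits leave unreadable from compound 1 to compound 3. None of them gives a readable size beyond the scatter. Among these compounds, only compound 2 has an exact number, 21000 nM. No step beyond the scatter is therefore expected in this assay, although hydroxy itself has not yet been measured on the shared core. The expected step is an at least 1.0-fold lower number from compound 3 to compound 4 (0.03 log units; that floor lies within the scatter). For compound 4 the estimated value is 23000 nM, with an expected range of 11000 nM to 45000 nM.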

Compound 4, half-maximal effective concentration: > 25000 nM
Compound 4 was reported as a limit; the forecaster's own chance of this, stated with the estimate: 55%; at least 1.0-fold (0.03 log units) between middle value and limit.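

In this assay, the change to hydroxy on this aromatic carbon, para to a large group, gives another limit rather than an exact number, so a third substituent now ends at the same point: the limit of > 25000 nM in this assay, at which 3 of the 4 values shown sit. Hydroxy brings a hydrogen-bond donor and a hydrogen-bond acceptor where trifluoromethyl has neither, yet this change still gives no exact value. For the compounds shown here, the only readable comparison is an at least 1.1-fold higher number from compound 2 to compound 4 (0.07 log units; that floor lies within the scatter), and the steps to compound 4 from compound 1 and compound 3 cannot be read.

Going by these compounds, the true values of compound 1, compound 3 and compound 4 remain unknown, so their order cannot be told. On these data alone, it also remains open whether an amine or a carboxylic acid at this position would give an exact value in this assay.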